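This account rests on a few compounds, and the source may have more. Where it says the series, first, only, none or still open, it means among the compounds named here.

Series notes, cytotoxicity arm.

Compound 1 `COc1ccc(CN(Cc2ccc(C(C)(C)C)cc2)Cc2cc3cc(C)ccc3[nH]c2=O)cc1` carries a methoxy on its benzyl arm. In a toxicity assay on MDCK cells (Canis lupus familiaris) for cytotoxicity, read by crystal violet staining, with a stated time of 48 h (a lower number here means that less compound is tolerated, a higher number that more compound is tolerated), compound 1 gives > 10000 nM, which is a limit of the assay and not a number. Compound 2 `Cc1ccc2[nH]c(=O)c(CN(Cc3ccc(OC(F)(F)F)cc3)Cc3ccc(C(C)(C)C)cc3)cc2c1` is the matched trifluoromethoxy partner. In this assay compound 2 gives > 5000 nM, again a limit. Among the measured compounds shown here, the change between them is trifluoromethyl in place of methyl on an oxygen on an aromatic ring and the step it made is a step that the two limits leave unreadable from compound 1 to compound 2; both values sit at limits, the one at the limit of > 10000 nM in this assay, at which 2 of the 3 values shown sit, and the other at the limit of > 5000 nM in this assay, at which 1 of the 3 values shown sits, so the pair tells only that neither compound is tolerated below its limit.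

Compound 3 `COc1ccc(C(C)N(Cc2ccc(C(C)(C)C)cc2)Cc2cc3cc(Br)ccc3[nH]c2=O)cc1Cl` belongs to a different core; the difference between the core of compound 3 and that of compound 1 is not broken down here. In this assay compound 3 gives > 10000 nM, a limit. Compound 4 `CC(c1ccc(OC(F)(F)F)c(Cl)c1)N(Cc1ccc(C(C)(C)C)cc1)Cc1cc2cc(Br)ccc2[nH]c1=O` is not yet measured and differs from compound 3 by trifluoromethyl in place of methyl on an oxygen on an aromatic ring, the same change as from compound 1 to compound 2, made at a place described in the same words.

For compound 4 in this assay the step from compound 3 is expected to be a step that the limit leaves unreadable from compound 3 to compound 4, resting on compound 3 sitting at > 10000 nM and on the pair at the limit of > 10000 nM in this assay, at which 2 of the 3 values shown sit, and the limit of > 5000 nM in this assay, at which 1 of the 3 values shown sits, showing no readable shift. Compound 4 is therefore estimated at 15000 nM, between 6000 nM and 50000 nM, most likely reported as a limit.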

Compound 4, half-maximal cytotoxic concentration: > 10000 nM
Compound 4 was reported as a limit (the forecaster's own chance of this, stated with the estimate: 80%); the middle value does not contradict the limit.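

Compound 3 and compound 4 both sit at a limit of the assay and not at a number, so no step between them can be read: the limit of > 10000 nM in this assay, at which 3 of the 4 values shown sit.

The compounds shown leave open where the actual values lie in this assay, and whether trifluoromethyl in place of methyl shifts them in either matched pair.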